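Lengthening the isothiocyanate linker on a fluorinated analogue

This account rests on a few compounds, and the source may have more. Where it says the series, first, only, none or still open, it means among the compounds named here.

Two compounds from this series have been examined in a functional assay on A549 cells (Homo sapiens) for inhibition, read by CCK-8 assay, with a stated time of 72 h, tested at 1 uM; a lower number here means a weaker effect, a higher number a stronger effect of the compound at the concentration tested. Compound 1, with the structure `CN(C)C(=O)c1cc2cnc(Nc3ccc(C(=O)NCCCCCCCN=C=S)cc3)nc2n1C1CCCC1`, gives 73.7% in this assay. Compound 2, with the structure `CN(C)C(=O)c1cc2cnc(Nc3ccc(C(=O)NCCCCCN=C=S)cc3F)nc2n1C1CCCC1`, gives -1.6% in this assay, the lowest of the two numbers, and it sits far below compound 1, a gap well beyond the scatter. Compound 2 carries a fluorine on the aromatic ring bearing the amide and a shorter isothiocyanate-bearing chain than compound 1, so the two values alone cannot say which of these two features accounts for the gap.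

Compound 3, with the structure `CN(C)C(=O)c1cc2cnc(Nc3ccc(C(=O)NCCCCCCCN=C=S)cc3F)nc2n1C1CCCC1`, takes one step from compound 2: a group of 5 heavy atoms (3 carbon, 1 nitrogen, 1 sulfur; no ring) in place of a group of 3 heavy atoms (1 carbon, 1 nitrogen, 1 sulfur; no ring), on a saturated chain carbon, five bonds along the chain from an amide-type nitrogen. This brings the chain to the length found in compound 1 while the fluorine of compound 2 remains. For the measured compounds named here, no comparable step between measured compounds is available, so the size of the effect in this assay is uncertain. An upward step from compound 2 is expected, a number 36.6 percentage points higher from compound 2 to compound 3 (beyond the scatter), but with wide uncertainty. Compound 3 is therefore estimated at 35% in this assay, within a range from 0% to 75%.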

Compound 3, a percentage reported as inhibition, at one concentration (the size of the read-out at that concentration, not a potency): 0.05%
The estimate for compound 3 lay 35 percentage points above the measured number; the measured number falls inside the stated range.
By their numbers in this assay, from the lowest: compounds 2 and 3 (each within the scatter of the next); then compound 1.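

With the fluoro group in place, the chain change at this position, on a saturated chain carbon, five bonds along the chain from an amide-type nitrogen, gives a number 1.7 percentage points higher from compound 2 to compound 3 (within the scatter) in this assay, so this change does not separate the two fluorinated compounds at the concentration tested. The gap that compound 2 left unassigned can now be read at a matched chain length: fluoro in place of hydrogen on an aromatic carbon gives a number 73.7 percentage points lower from compound 1 to compound 3 (beyond the scatter), which ties the large difference to that single change among these compounds. No supporting data bear on why this one substitution has so large an effect.

The compounds shown leave open whether chain length matters when the aromatic carbon carries hydrogen, since the shorter chain is seen only alongside the fluoro group. They also leave open whether a chloro or methyl group on that aromatic carbon would behave as the fluoro group does, and whether a longer chain would change the result with either hydrogen or fluoro there.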